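The source may hold more compounds than are shown below. What is called first, only, known or untested is meant among the compounds shown, and "the series" means these compounds.

Compound 1, `O=C(NCc1cc(Cl)ccc1-n1cnnn1)[C@@H]1[C@H]2C[C@H]2CN1C(=O)[C@H](O)CC1CC1`: 1400 nM in a functional assay on a cell-free system (plasma, Homo sapiens), with a stated time of 3 min; a lower number here means a stronger inhibitor, a higher number a weaker inhibitor.
Compound 2, `Cc1cccc([C@@H](O)C(=O)N2N=CC[C@H]2C(=O)NCc2cc(Cl)ccc2-n2cnnn2)c1`: 830 nM in this assay.
Compound 3, `O=C(NCc1cc(Cl)ccc1-n1cnnn1)[C@@H]1C[C@H]2C[C@H]2N1C(=O)[C@H](O)c1cccc(F)c1`: 1100 nM in this assay.

Compound 2 stands at the low end of the three numbers in this assay, but its gaps to compound 3 and to compound 1 both lie within the usual scatter, so the three cannot be told apart. Compound 4, `CC(C)(C)C[C@@H](O)C(=O)N1N=CC[C@H]1C(=O)NCc1cc(Cl)ccc1-n1cnnn1`, is not yet measured. It differs from compound 2 in one place: neopentyl in place of 3-methylphenyl on a saturated chain carbon bound to a carbonyl carbon and an oxygen on a saturated carbon. Going by the values given here, no measured pair shows this change, and the only aliphatic group at that position among the measured compounds sits on a different core in compound 1. Compound 4 is therefore expected to give a number in this assay near that of compound 2, with a step of a 1.8-fold higher number from compound 2 to compound 4 (0.26 log units; within the scatter) of modest size toward a weaker inhibitor. The estimate for compound 4 in this assay is 1500 nM, in the range 500 nM to 4500 nM.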

Compound 4, half-maximal inhibitory concentration: 590 nM
Compound 4: middle estimate off by 2.5-fold (0.41 log units), on the high side, and the stated range covers the measured number.
By their numbers in this assay, from the lowest: compounds 4, 2, 3 and 1 (each within the scatter of the next, the first and the last beyond it).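

In this assay the change to neopentyl gives a 1.4-fold lower number from compound 2 to compound 4 (0.15 log units; within the scatter) on the shared core, the first step read at this position. Going by these compounds alone, at this place on the shared core, then, a group with no ring reads the same as one with a six-membered aromatic ring, a comparison the earlier compounds, which differ in more than one place, could not offer. Nothing measured here says why the two groups read alike. Going by these compounds, whether an amine, a carboxylic acid or a longer chain would also read alike stays open. So does whether this change would read the same on the core of compound 1 or compound 3.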